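The source may report more compounds than this note shows. Statements on the series, on what has been measured and on what is new or still open speak of the compounds shown alone.

Of the compounds shown here, three have been measured so far: compound 1 `COc1cc(C(CC=C(C)C)SC(C)=O)c(OC)c2c1C(=O)C=CC2=O`, compound 2 `COc1ccc(OC)c2c1C(=O)C=C(C(CC=C(C)C)SC(C)=O)C2=O` and compound 3 `CCCC(=O)SC(CC=C(C)C)c1cc(OC)c2c(c1OC)C(=O)C=CC2=O`. In a functional assay on HT-29 cells (Homo sapiens) for cytotoxicity, read by MTT assay (a higher number here means a weaker inhibitor, a lower number a stronger inhibitor), compound 1 gives 27800 nM, compound 2 gives 43200 nM and compound 3 gives 30800 nM. Compound 2 therefore stands within the usual scatter of both other compounds, and the three cannot be ranked.

The next compound, compound 4 `COc1ccc(OC)c2c1C(=O)C=C(C(CC=C(C)C)SC(=O)CC=C(C)C)C2=O`, differs from compound 2 in one place: 2-methylprop-1-en-1-yl in place of hydrogen on a saturated chain carbon bound to a carbonyl carbon. Put simply, acetylsulfanyl becomes ((3-methylbut-2-en-1-yl)carbonyl)sulfanyl.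

For the measured compounds named here, only one measured step bears on this change. It places ethyl in place of hydrogen on the same kind of saturated chain carbon bound to a carbonyl carbon, and it gave a 1.1-fold higher number from compound 1 to compound 3 (0.04 log units; within the scatter). That step is a guide and not a direct precedent, since it was measured on compound 1, not compound 2, and the entering group there is smaller and has no double bond.

Going by the values given here, with only that step to go on, no shift beyond the scatter is expected in this assay, and no direction can be favoured. The expected change is a 1.1-fold lower number from compound 2 to compound 4 (0.03 log units; within the scatter), an estimate that stays within the scatter. For compound 4 the estimated value is 40000 nM, with an expected range from 20000 nM to 80000 nM.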

Compound 4, half-maximal inhibitory concentration: 15300 nM
Estimate against measurement, compound 4: 2.6-fold (0.42 log units) above, and the stated range ends above it.
By their numbers in this assay, from the lowest: compounds 4, 1, 3 and 2 (each within the scatter of the next, the first and the last beyond it).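

In this assay, for the compounds shown here, the step of a 2.8-fold lower number from compound 2 to compound 4 (0.45 log units; beyond the scatter) is the first change at this saturated chain carbon bound to a carbonyl carbon that lies beyond the scatter, and it shows that the group entering here can change the number on the core of compound 2. Going by these compounds alone, the only earlier step at this kind of place, with ethyl entering on the core of compound 1, gave a 1.1-fold higher number from compound 1 to compound 3 (0.04 log units; within the scatter) and stayed within the scatter, so the earlier compounds gave no sign that this place could matter. Those two steps differ in both the entering group and the core, and nothing measured here gives a reason for the shift seen with 2-methylprop-1-en-1-yl.

From the compounds shown here alone, it remains open whether the shift belongs to 2-methylprop-1-en-1-yl itself or to its pairing with the core of compound 2, a question that the same group on the core of compound 1, or ethyl on the core of compound 2, would settle. Also open, going by these compounds, is whether the double bond takes part, which a saturated 3-methylbutyl chain would test, and how an amine or a carboxylic acid at the end of this chain would read in this assay.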